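The source may hold more compounds than are shown below. What is called first, only, known or untested is meant among the compounds shown, and "the series" means these compounds.

Measured compounds:

Compound 1, `O=c1cc(-c2ccccc2)oc2cc(OCCCCNc3nc4ccccc4s3)cc(O)c12`: in a functional assay on SK-OV-3 cells (Homo sapiens) for cytotoxicity, read by sulforhodamine B assay, with a stated time of 48 h (on this read-out lower numbers stand for stronger inhibition and higher numbers for weaker inhibition), compound 1 gives 48.5 ug/mL.
Compound 2, `Cc1ccc2nc(NCCCCOc3cc(O)c4c(=O)cc(-c5ccccc5)oc4c3)sc2c1`: in this assay compound 2 gives 48.4 ug/mL.
Compound 3, `O=c1cc(-c2ccccc2)oc2cc(OCCCCNc3nc4ccc([N+](=O)[O-])cc4s3)cc(O)c12`: in this assay compound 3 gives 41.4 ug/mL.

Compound 3 holds the smallest of the three numbers, but the step of a 1.2-fold lower number from compound 1 to compound 3 (0.07 log units; within the scatter) and the step of a 1.2-fold lower number from compound 2 to compound 3 (0.07 log units; within the scatter) both lie within the scatter, as does the step of a 1.0-fold lower number from compound 1 to compound 2 (0.00 log units; within the scatter). The three measured compounds are therefore not separated from one another on this read-out.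

Compound 4, `O=c1cc(-c2ccccc2)oc2cc(OCCCCNc3nc4ccc(Cl)cc4s3)cc(O)c12`, has not yet been measured. It differs from compound 3 by chloro in place of nitro on an aromatic carbon. Going by the values given here, the steps that bear on this position are the change from hydrogen to nitro, a 1.2-fold lower number from compound 1 to compound 3 (0.07 log units; within the scatter), and the change from methyl to nitro, a 1.2-fold lower number from compound 2 to compound 3 (0.07 log units; within the scatter); neither moved the number beyond the scatter. A third substituent at the same place is accordingly expected to leave the number essentially where it is.

Compound 4 is therefore estimated to give 45 ug/mL in this assay, with a range from 28 ug/mL to 72 ug/mL. That estimate corresponds to an expected step of a 1.1-fold higher number from compound 3 to compound 4 (0.04 log units; within the scatter), which is not expected to exceed the scatter.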

Compound 4, half-maximal inhibitory concentration: 39.3 ug/mL
Compound 4: middle estimate off by 1.1-fold (0.06 log units), on the high side, and the stated range covers the measured number.
By their numbers in this assay, from the lowest: compounds 4, 3, 2 and 1 (each within the scatter of the next).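

Chloro, a single heavy atom with no hydrogen-bond acceptors, replaces nitro, with three heavy atoms and two hydrogen-bond acceptors, and this assay records a 1.1-fold lower number from compound 3 to compound 4 (0.02 log units; within the scatter), so this large difference in the counted atoms does not separate the two compounds. The other two comparisons, a 1.2-fold lower number from compound 2 to compound 4 (0.09 log units; within the scatter) and a 1.2-fold lower number from compound 1 to compound 4 (0.09 log units; within the scatter), also stay within the scatter, which extends the flat picture at this aromatic carbon to four substituents: hydrogen, methyl, nitro and chloro. No measurement shown here accounts for this flat result.

From the compounds shown here alone, whether an amine or a carboxylic acid at this place, or a longer chain linking the two ring systems, would move the number beyond the scatter remains open. Also open, going by these compounds, is whether a chloro or nitro group on another carbon of the same ring would give a different number.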